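A few compounds are considered here, and "the series" means these few. Any claim that something is new, unique, unknown or untested is made for them only; others in the source may bear on it.

Compound 1 `CCc1nnc(NC(=O)Cn2c(-c3ccccc3)cc(-c3ccccc3)c2-c2ccco2)s1` gives 81% in an ADME assay on HEK-293T cells (Homo sapiens) for cytotoxicity, read by MTT assay, with a stated time of 72 h, tested at 50 uM; a higher number here means more inhibition at the concentration tested (going by the name of the read-out), a lower number less inhibition.
Compound 2 `O=C(Cn1c(-c2ccc3ccccc3c2)cc(-c2ccccc2)c1-c1ccco1)Nc1nc2ccccc2s1` gives 38.3% in this assay.

Of these two numbers compound 2 stands lowest; its nearest neighbour is compound 1, whose value lies higher by a margin beyond the usual scatter of this kind of measurement. Compound 3 `CCc1nnc(NC(=O)Cn2c(-c3ccc4ccccc4c3)cc(-c3ccccc3)c2-c2ccco2)s1` has not yet been measured. It is built from compound 2 by a single exchange on an amide-type nitrogen whose other neighbour is a carbonyl carbon: 5-ethyl-1,3,4-thiadiazol-2-yl in place of 1,3-benzothiazol-2-yl on an amide-type nitrogen. Going by the values given here, the group that enters is the one that compound 1 carries at the same place, while the remainder of compound 3 follows compound 2. Among the compounds with values here, no measured pair of compounds differs in this place alone, so the size of the step cannot be read off directly; the only guide is compound 1, which carries the same entering group and gives 81%. On that guide an upward step in this assay is expected for compound 3, of a size beyond the scatter, and the expected step is a number 26.7 percentage points higher from compound 2 to compound 3 (beyond the scatter). Compound 3 is estimated at 65%, with a range from 40% to 85%.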

Compound 3, a percentage reported as inhibition, at one concentration (the size of the read-out at that concentration, not a potency): 83.6%
Beside the measured number, compound 3's estimate is 18.6 percentage points below it; the measured number falls inside the stated range.
By their numbers in this assay, from the lowest: compound 2; then compounds 1 and 3 (each within the scatter of the next).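

Seen on its own, with the rest of the molecule held fixed, the exchange of 1,3-benzothiazol-2-yl for 5-ethyl-1,3,4-thiadiazol-2-yl on the amide-type nitrogen gives in this assay a number 45.3 percentage points higher from compound 2 to compound 3 (beyond the scatter) and so counts as a large change at this position. The second exchange, naphthalen-2-yl in place of phenyl on an aromatic carbon, gives a number 2.6 percentage points higher from compound 1 to compound 3 (within the scatter) and cannot be told apart from repeat scatter when 5-ethyl-1,3,4-thiadiazol-2-yl is present, so the amide-type nitrogen, rather than this aromatic carbon, is the place where a large step is seen among these compounds. Nothing shown here accounts for the size of the step at the amide-type nitrogen.

From the compounds shown here alone, it remains open whether the step depends on the ring of the entering group or on its ethyl chain, which a 5-methyl-1,3,4-thiadiazol-2-yl group, a 5-propyl-1,3,4-thiadiazol-2-yl group or a plain 1,3,4-thiadiazol-2-yl group could help to separate. Going by these compounds, it is also open whether naphthalen-2-yl and phenyl would remain as close with 1,3-benzothiazol-2-yl on the amide-type nitrogen, and whether a simple phenyl or a pyridin-2-yl group there would behave like either ring system.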